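Bromomethyl in Place of Methoxycarbonyl: Expected Cytotoxicity

The source may hold more compounds than are shown below. What is called first, only, known or untested is meant among the compounds shown, and "the series" means these compounds.

Among the compounds with values here, compound 1 `CCc1cccc2c(OC)c(-c3occ(C)c3C(=O)OC)ccc12` gives 1.3 ug/mL in a functional assay on KBVIN cells (Homo sapiens) for cytotoxicity, read by MTT assay, with a stated time of 72 h (a higher number here means that more compound is needed for the effect, a lower number that less compound is needed), and stands lowest of the two numbers measured so far; compound 2 `CCc1cccc2c(OC)c(-c3occ(C)c3CO)ccc12` gives 6.6 ug/mL in this assay. Within the data shown here, the one measured step, a 5.1-fold higher number from compound 1 to compound 2 (0.71 log units; beyond the scatter), removes the same methoxycarbonyl that compound 3 `CCc1cccc2c(OC)c(-c3occ(C)c3CBr)ccc12` also loses: bromomethyl in place of methoxycarbonyl on an aromatic carbon. Among the measured compounds shown here, that step is the only guide here, and it points toward a higher number, though bromomethyl is not hydroxymethyl, so the size is uncertain and a smaller shift would not surprise. Compound 3 is therefore expected to give 3 ug/mL in this assay, with a range of 0.8 ug/mL to 12 ug/mL. The expected step is a 2.3-fold higher number from compound 1 to compound 3 (0.36 log units; beyond the scatter).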

Compound 3, concentration for half-maximal effect: > 10 ug/mL
Compound 3: only a limit was reported; the forecaster's own chance of this, stated with the estimate: 5%; at least 3.3-fold (0.52 log units) between middle value and limit.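

Compound 3 is reported only as a limit in this assay: the limit of > 10 ug/mL in this assay, at which 1 of the 3 values shown sits. Bromomethyl in place of methoxycarbonyl gives an at least 7.6-fold higher number from compound 1 to compound 3 (0.88 log units; beyond the scatter), so at this carbon both replacements shown, bromomethyl and hydroxymethyl, move the number the same way, the latter with a 5.1-fold higher number from compound 1 to compound 2 (0.71 log units; beyond the scatter). Bromo in place of hydroxy gives an at least 1.5-fold higher number from compound 2 to compound 3 (0.18 log units; that floor lies within the scatter), so the floor of this step does not separate the two compounds.

Going by these compounds, how far compound 3 lies past its limit stays open. Also open, on these data alone, is whether a carboxylic acid or a primary amide at this carbon would stay near compound 1.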